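From a free phenol to its benzyl ether

The compounds below may be only part of what the source reports. "The series", "measured", "known", "first", "only" and "open" are said of these compounds alone.

Compound 1: `COc1cccc(COc2ccc3cc(C(=O)/C=C/c4cccc(OC)c4OC)c(=O)oc3c2)c1`, 22800 nM
Compound 2: `COc1cccc(COc2ccc3cc(C(=O)/C=C/c4cc(OC)ccc4OC)c(=O)oc3c2)c1`, 13800 nM
Compound 3: `COc1cccc(/C=C/C(=O)c2cc3cc(O)ccc3oc2=O)c1OC`, 6700 nM

In a functional assay on MOLT-4 cells (Homo sapiens) for cytotoxicity, read by MTT assay, with a stated time of 72 h (a higher number here means a weaker inhibitor, a lower number a stronger inhibitor), compound 3 gives the lowest of the three numbers; compound 2 stands beyond the scatter above it, and compound 1 further still. Compound 4 `COc1cccc(/C=C/C(=O)c2cc3cc(OCc4ccccc4)ccc3oc2=O)c1OC` has not yet been measured. (benzyl in place of hydrogen on an oxygen on an aromatic ring). For the measured compounds named here, no measured step touches this oxygen: the single measured step, a 1.7-fold lower number from compound 1 to compound 2 (0.22 log units; within the scatter), alters the other ring and lies within the scatter. What the values do show is that compound 1, which carries a substituted ether on this oxygen while sharing the 2,3-dimethoxyphenyl of compound 3, sits well above compound 3. On that basis a modestly higher number is expected for compound 4, a 2.2-fold higher number from compound 3 to compound 4 (0.35 log units; beyond the scatter). The estimate for compound 4 is 15000 nM, with a range from 5000 nM to 45000 nM.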

Compound 4, half-maximal inhibitory concentration: 23600 nM
Compound 4: the middle estimate sits 1.6-fold (0.20 log units) below what was measured; the measured number falls inside the stated range.
By their numbers in this assay, from the lowest: compound 3; then compounds 2, 1 and 4 (each within the scatter of the next).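

In this assay, the step at this oxygen can now be read directly: a 3.5-fold higher number from compound 3 to compound 4 (0.55 log units; beyond the scatter), so replacing hydroxy with benzyloxy on an otherwise unchanged structure raises the number. Compound 1 gives 22800 nM and compound 4 gives 23600 nM, which lie within the scatter of each other, so the methoxy on the benzyl of compound 1 makes no readable difference here. No available measurement explains the rise.

As far as these compounds go, it remains open whether a methyl ether, or an amine or carboxylic acid on a longer chain at this oxygen, would stand nearer compound 3 or compound 4. From the compounds shown here alone, it is also open whether the step holds with the 2,5-dimethoxyphenyl of compound 2.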